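Swapping fluoro for chloro on the second benzoyl ring

This account rests on a few compounds, and the source may have more. Where it says the series, first, only, none or still open, it means among the compounds named here.

Measured so far:
- compound 1, `CC(C)(C)N(NC(=O)c1ccccc1)C(=O)c1ccccc1F`: in an assay on cells for agonist activity at ecdysone receptor (Bombyx mori), read by a luciferase reporter, with a stated time of 24 h (a lower number here means that less compound is needed, a higher number that more compound is needed for the effect), compound 1 gives 309 nM
- compound 2, `CC(C)(C)N(NC(=O)c1ccccc1)C(=O)c1ccccc1Cl`: in this assay compound 2 gives 75.9 nM
- compound 3, `CC(C)(C)N(NC(=O)c1cccc(F)c1)C(=O)c1ccccc1Cl`: in this assay compound 3 gives 69.2 nM

Compound 1 and compound 2 differ in a single place, (chloro in place of fluoro on an aromatic carbon), and that single swap produced a 4.1-fold lower number from compound 1 to compound 2 (0.61 log units; beyond the scatter). Compound 3 then adds one more atom to the other ring, and this gave a 1.1-fold lower number from compound 2 to compound 3 (0.04 log units; within the scatter), so compound 2 and compound 3 cannot be told apart on these numbers.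

Compound 4, `CC(C)(C)N(NC(=O)c1cccc(Cl)c1)C(=O)c1ccccc1Cl`, has not yet been measured. It differs from compound 3 by chloro in place of fluoro on an aromatic carbon. For the measured compounds named here, this is the same kind of change as the one from compound 1 to compound 2, but not the same: there the new chloro sat ortho to a large group, here it sits meta to a large group. The difference between the core of compound 1 and the core of compound 3 is not broken down here.

Going by the values given here, the only guide is that the earlier swap gave a 4.1-fold lower number from compound 1 to compound 2 (0.61 log units; beyond the scatter) from compound 1 to compound 2; a smaller gain is expected at the new place, so the step from compound 3 to compound 4 is estimated at a 1.7-fold lower number from compound 3 to compound 4 (0.24 log units; within the scatter). Compound 4 is therefore expected to give about 40 nM, plausibly between 15 nM and 110 nM.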

Compound 4, half-maximal effective concentration: 155 nM
Estimate against measurement, compound 4: 3.9-fold (0.59 log units) below; the whole stated range lies below it.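

In this assay, changing 3-fluorophenyl to 3-chlorophenyl gave a 2.2-fold higher number from compound 3 to compound 4 (0.35 log units; beyond the scatter), and chloro in place of hydrogen at that same place gave a 2.0-fold higher number from compound 2 to compound 4 (0.31 log units; beyond the scatter). Set beside the earlier swap, this shows that exchanging fluoro for chloro does not carry a fixed gain from one core to another in this series, since the number fell on one core and rose on the other, by clearly different amounts: the same change on two cores in this assay, a 4.1-fold lower number (0.61 log units; beyond the scatter) from compound 1 to compound 2 and a 2.2-fold higher number (0.35 log units; beyond the scatter) from compound 3 to compound 4, 9.1-fold (0.96 log units) apart, beyond the scatter of two such steps It does not show what lies behind the difference, since the two swaps sit at different places on different rings, the cores differ as well, and a single pair of steps cannot separate these factors or give a rule for other cores.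

Going by these compounds, what stays open is whether the rise seen with chloro is specific to that atom, or whether a larger group such as methyl or methoxy, meta to a large group on the same ring, would also give a higher number than compound 2 does. On these data alone, it is equally open how bromo or a nitrile at that place would compare with the fluoro of compound 3.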